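The compounds below may be only part of what the source reports. "The series", "measured", "known", "first", "only" and "open" are said of these compounds alone.

Measured so far in a functional assay on COLO 205 cells (Homo sapiens) for antiproliferative activity, read by sulforhodamine B assay, with a stated time of 72 h; a higher number here means a weaker inhibitor, a lower number a stronger inhibitor:
Compound 1 `C(=C/c1ccccc1)\C(=N\Nc1nncc2ccccc12)c1ccccc1` gives 2.4 nM
Compound 2 `S=C(NNc1nncc2ccccc12)Nc1ccccc1` gives 77 nM
Compound 3 `COc1ccc(NC(=S)NNc2nncc3ccccc23)cc1` gives 67 nM

Compound 2 stands well above compound 1 on these numbers. Compound 4 `NC(=S)NNc1nncc2ccccc12` differs from compound 2 by hydrogen in place of phenyl on an amide-type nitrogen. Going by the values given here, the only measured step, a 1.1-fold lower number from compound 2 to compound 3 (0.06 log units; within the scatter) with methoxy in place of hydrogen on an aromatic carbon, keeps that phenyl, so it bears only weakly on this change. Among the compounds with values here, no measured pair shows the phenyl being lost. Removing the whole group is a larger change, and a modest rise in this assay is tentatively expected, an estimated 2.6-fold higher number from compound 2 to compound 4 (0.41 log units; beyond the scatter) with wide uncertainty. For compound 4 the expected value is 200 nM (estimated range 50 nM to 800 nM).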

Compound 4, half-maximal inhibitory concentration: 55 nM
Compound 4: the middle estimate sits 3.6-fold (0.56 log units) above what was measured; measured number inside the range.
By their numbers in this assay, from the lowest: compound 1; then compounds 4, 3 and 2 (each within the scatter of the next).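

In this assay, the step of a 1.4-fold lower number from compound 2 to compound 4 (0.15 log units; within the scatter) shows that the whole phenyl can leave the amide-type nitrogen, not merely be decorated, with no change beyond the scatter. The anilino to amino change therefore leaves the number where it was, and the ring on this nitrogen is not required to hold that level among these compounds. No available evidence explains this result. Going by these compounds, whether a methyl, a benzyl or a longer alkyl chain on this nitrogen would behave in the same way remains open. So does the effect of a carbonyl in place of the thiocarbonyl.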